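Swapping chloro for fluoro on compound 2

A few compounds are considered here, and "the series" means these few. Any claim that something is new, unique, unknown or untested is made for them only; others in the source may bear on it.

In an ADME assay on L6 cells (Rattus norvegicus) for cytotoxicity, read by fluorescence and resazurin assay, with a stated time of 72 h (a lower number here means that less compound is tolerated, a higher number that more compound is tolerated), compound 2 `Cc1ccc(C(c2ccn(-c3ccc(Cl)cc3)c2)n2ccnc2)cc1` gives 42600 nM and stands within the scatter of compound 3 `Fc1ccc(C(c2ccn(-c3ccc(Cl)cc3)c2)n2ccnc2)cc1` at 63100 nM on this scale. Compound 1 `Clc1ccc(C(c2c[nH]cc2-c2cccc3ccccc23)n2ccnc2)c(Cl)c1` at 12300 nM lies clearly lower than both.

Compound 4 `Cc1ccc(C(c2ccn(-c3ccc(F)cc3)c2)n2ccnc2)cc1` differs from compound 2 by a single swap fluoro in place of chloro on an aromatic carbon that puts fluoro in place of chloro on an aromatic carbon. Going by the values given here, the one measured step that bears on this also brings in fluoro, though there it is methyl that gives way, and it was a 1.5-fold higher number from compound 2 to compound 3 (0.17 log units; within the scatter) with no larger step to go by. So no step beyond the scatter is expected in this assay for this swap. The expected change is a 1.1-fold higher number from compound 2 to compound 4 (0.05 log units; within the scatter) and no more. For compound 4 the estimate is 48000 nM with an expected range from 24000 nM to 95000 nM as the likely span.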

Compound 4, half-maximal cytotoxic concentration: 60700 nM
For compound 4 the middle estimate is 1.3-fold (0.10 log units) below the measured one, within the range that was stated.
By their numbers in this assay, from the lowest: compound 1; then compounds 2, 4 and 3 (each within the scatter of the next).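

Where the earlier step replaced the methyl, this one changes the chloro itself: in this assay there is a 1.4-fold higher number from compound 2 to compound 4 (0.15 log units; within the scatter) when 4-chlorophenyl becomes 4-fluorophenyl. For this pair, then, swapping chloro for fluoro at this position leaves the cells' tolerance within the usual scatter. Nothing measured here offers an explanation for this result.

The compounds shown cover only these two small atoms at this position. Going by these compounds, whether an amine, a carboxylic acid or a longer chain in the same place would leave tolerance just as unchanged remains open.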